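This account rests on a few compounds, and the source may have more. Where it says the series, first, only, none or still open, it means among the compounds named here.

Measured compounds:
- compound 1 `c1ccc2c(c1)CCC2NC1CCN(CCCc2c[nH]c3ccc(-n4cnnc4)cc23)CC1` gives 280 nM
- compound 2 `CC(=O)Nc1ccc([C@H](C)NCC2CCN(CCCc3c[nH]c4ccc(-n5cnnc5)cc34)CC2)cc1` gives 9.3 nM
- compound 3 `CC(C)=CCN(C)C1CCN(CCCc2c[nH]c3ccc(-n4cnnc4)cc23)CC1` gives 41 nM

These three share one core and differ only in the group attached to the saturated ring carbon of the piperidine. In an assay on CHO cells for displacement of a labelled ligand from 5-hydroxytryptamine receptor 1B (Homo sapiens) (a lower number here means a stronger inhibitor, a higher number a weaker inhibitor), compound 3 stands second of the three numbers: compound 2 gives the lowest number, and compound 1 the highest. For the measured compounds named here, the one step measured within this set, a 6.8-fold lower number from compound 1 to compound 3 (0.83 log units; beyond the scatter), shows that swapping the group on that carbon can move the number by a modest but real amount.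

Compound 4 `c1ccc(NCC2CCN(CCCc3c[nH]c4ccc(-n5cnnc5)cc34)CC2)nc1` is the next change from compound 3: ((pyridin-2-yl)amino)methyl in place of methyl(3-methylbut-2-en-1-yl)amino on a saturated ring carbon. Going by the values given here, no measured step matches this exchange directly. Compound 2, which also carries an aminomethyl arm ending in an aromatic ring on the same carbon, gives the lowest number of the set, which suggests a group of this kind is at least tolerated. On that basis a small step downward is expected, a 1.5-fold lower number from compound 3 to compound 4 (0.17 log units; within the scatter), with compound 4 estimated at 28 nM and a likely range from 8 nM to 110 nM.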

Compound 4, half-maximal inhibitory concentration: 3.3 nM
Compound 4: middle estimate off by 8.5-fold (0.93 log units), on the high side; the measured number lies below the stated range.
By their numbers in this assay, from the lowest: compound 4; then compound 2; then compound 3; then compound 1.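

In this assay, for the compounds shown here, the group on this saturated ring carbon can move the number much further than the earlier compounds showed: there is a 12-fold lower number from compound 3 to compound 4 (1.09 log units; beyond the scatter), and the widest gap in the set is an 85-fold lower number from compound 1 to compound 4 (1.93 log units; beyond the scatter), both large steps. The aromatic ring of the arm can also sit directly on the amine nitrogen, with no 1-(4-acetamidophenyl)ethyl needed, since pyridin-2-yl in its place gives a 2.8-fold lower number from compound 2 to compound 4 (0.45 log units; beyond the scatter), a modest step beyond the scatter. Nothing available explains why these exchanges change the number as they do.

Still open, going by these compounds, is which part of ((pyridin-2-yl)amino)methyl carries the gain, for instance whether a phenyl or a pyrimidin-2-yl on that amine nitrogen would hold the number. On these data alone, it is equally open whether an ether oxygen could stand in place of the amine nitrogen.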